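The compounds below may be only part of what the source reports. "The series", "measured", "known", "first", "only" and "open" are said of these compounds alone.

Measured in a functional assay on HeLa cells (Homo sapiens) for antiproliferative activity, with a stated time of 48 h; on this read-out lower numbers stand for stronger inhibition and higher numbers for weaker inhibition:
- Compound 1 `C=C(Br)C(=O)Nc1ccc(/C=C/C(=O)c2ccc(C)cc2)cc1` gives 2100 nM
- Compound 2 `C=C(Br)C(=O)Nc1ccc(/C=C/C(=O)c2ccc(OC)cc2)cc1` gives 1400 nM
- Compound 3 `C=C(Br)C(=O)Nc1ccc(/C=C/C(=O)c2ccc(OCC)cc2)cc1` gives 750 nM

Compound 3 stands at the low end of these numbers, together with compound 2. The measured gaps are a 1.9-fold lower number from compound 2 to compound 3 (0.27 log units; within the scatter) and a 2.8-fold lower number from compound 1 to compound 3 (0.45 log units; beyond the scatter). Compound 4 `CCOc1ccc(C(=O)/C=C/c2ccc(N)cc2)cc1` follows from compound 3 by one change: hydrogen in place of (1-bromoethenyl)carbonyl on a nitrogen on an aromatic ring. The measured steps, including a 1.5-fold lower number from compound 1 to compound 2 (0.18 log units; within the scatter), all alter the group on an aromatic carbon, and none touches this nitrogen. They therefore give no direct measure of the change. Every measured compound keeps the (1-bromoethenyl)carbonyl, so its loss is judged without precedent here, and a step beyond the scatter toward a higher number is expected in this assay. The expected step is a 16-fold higher number from compound 3 to compound 4 (1.20 log units; beyond the scatter). Compound 4 is estimated at 12000 nM, within an expected range of 3000 nM to 45000 nM.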

Compound 4, half-maximal inhibitory concentration: 41000 nM
The estimate for compound 4 lay 3.4-fold (0.53 log units) below the measured number, and the stated range covers the measured number.
By their numbers in this assay, from the lowest: compounds 3, 2 and 1 (each within the scatter of the next, the first and the last beyond it); then compound 4.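

In this assay removing the (1-bromoethenyl)carbonyl from the nitrogen on the aromatic ring gives a 55-fold higher number from compound 3 to compound 4 (1.74 log units; beyond the scatter) and so shows that this nitrogen position weighs far more than the changes on the aromatic carbon, the largest of which is a 2.8-fold lower number from compound 1 to compound 3 (0.45 log units; beyond the scatter) in this set. Nothing available explains the size of this loss. From the compounds shown here alone, what stays open is which part of the (1-bromoethenyl)carbonyl counts: whether a plain acetyl or an acryloyl without bromine on the same nitrogen would stay near compound 3 or fall toward compound 4.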